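From Nitro to Bromo on the Shared Core

The compounds below may be only part of what the source reports. "The series", "measured", "known", "first", "only" and "open" are said of these compounds alone.

Of the compounds shown here, three have been measured so far in an ADME assay on Vero cells (Chlorocebus sabaeus) for inhibition; on this read-out lower numbers stand for higher toxicity in this test and higher numbers for lower toxicity in this test. Compound 1 `COc1cccc(/C=C2\CCCCC2=O)c1OC` gives 720000 nM, compound 2 `COc1ccc(/C=C2\CCC/C(=C\c3ccccc3)C2=O)cc1` gives 291000 nM, and compound 3 `COc1ccc(/C=C2\CCC/C(=C\c3ccc([N+](=O)[O-])cc3)C2=O)cc1` gives 435000 nM. The number for compound 3 lies within the usual scatter of both of the others, so it cannot be clearly separated from either.

Compound 4 `COc1ccc(/C=C2\CCC/C(=C\c3ccc(Br)cc3)C2=O)cc1` is not yet measured. It differs from compound 3 by one change: bromo in place of nitro on an aromatic carbon. The swap is bromo in place of nitro on an aromatic carbon.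

Within the data shown here, no measured compound carries bromo, so the evidence is indirect. Among the measured compounds shown here, the only measured step that bears on this change is a 1.5-fold higher number from compound 2 to compound 3 (0.17 log units; within the scatter), with nitro in place of hydrogen on an aromatic carbon. That step stays within the scatter, so no step beyond the scatter is expected in this assay.

The expected step is a 1.3-fold lower number from compound 3 to compound 4 (0.12 log units; within the scatter). For compound 4 the estimated value is 330000 nM, with an expected range from 160000 nM to 680000 nM.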

Compound 4, half-maximal cytotoxic concentration: 250000 nM
Compound 4: the middle estimate sits 1.3-fold (0.12 log units) above what was measured, and the stated range covers the measured number.
By their numbers in this assay, from the lowest: compounds 4, 2, 3 and 1 (each within the scatter of the next, the first and the last beyond it).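

In this assay, this place on the aromatic ring, para to a large group, has now carried hydrogen, nitro and bromo, and the three compounds cannot be told apart. Bromo in place of nitro gives a 1.7-fold lower number from compound 3 to compound 4 (0.24 log units; within the scatter), and bromo in place of hydrogen gives a 1.2-fold lower number from compound 2 to compound 4 (0.07 log units; within the scatter), so both steps stay within the scatter, even though bromo has one heavy atom and nitro has three. Nothing measured here explains why these groups read alike.

On these data alone, whether an amine or a carboxylic acid at this same place would give a step beyond the scatter remains open. Also open, as far as these compounds go, is whether the same holds on another core, since compound 1 differs from the others in more than one place and cannot be compared with them step by step.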